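This account rests on a few compounds, and the source may have more. Where it says the series, first, only, none or still open, it means among the compounds named here.

Measured so far in a functional assay on HUVEC cells (Homo sapiens) for inhibition, tested at 5 ug/mL; a lower number here means a weaker effect, a higher number a stronger effect of the compound at the concentration tested:
Compound 1, `COc1cc(/C=C/C(=O)c2cccc(N)c2)ccc1O`, gives 50%.
Compound 2, `COC(=O)C(=O)Nc1cccc(C(=O)/C=C/c2ccc(O)c(OC)c2)c1`, gives 20%.
Compound 3, `CCCC(=O)Nc1cccc(C(=O)/C=C/c2ccc(O)c(OC)c2)c1`, gives 57%.

Compound 3 holds the highest of the three numbers, but the step of a number 7 percentage points higher from compound 1 to compound 3 (within the scatter) lies within the scatter, so compound 1 and compound 3 cannot be ordered against each other. Only compound 2 is clearly set apart, as the step of a number 37 percentage points higher from compound 2 to compound 3 (beyond the scatter) shows; the step of a number 30 percentage points lower from compound 1 to compound 2 (beyond the scatter) points the same way.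

Compound 4, `COc1cc(/C=C/C(=O)c2cccc(NC(=O)c3ccccc3)c2)ccc1O`, is the next point in the series. Its difference from compound 3 is phenyl in place of propyl on a carbonyl carbon.

Two of the measured steps touch the same place. The step of a number 37 percentage points higher from compound 2 to compound 3 (beyond the scatter) exchanges the group on this carbonyl carbon and is large; the steps of a number 30 percentage points lower from compound 1 to compound 2 (beyond the scatter) and a number 7 percentage points higher from compound 1 to compound 3 (within the scatter) show that what is attached to the ring nitrogen can move the number down or leave it unchanged. Among the measured compounds shown here, no measured pair swaps propyl for phenyl, so the direction of the present change is not fixed by the data. With propyl and phenyl both being hydrocarbon groups on this carbonyl carbon, the expected step for compound 4 is a number 5 percentage points lower from compound 3 to compound 4 (within the scatter), not beyond the scatter. Compound 4 is therefore estimated at 52%, in the range 25% to 75%.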

Compound 4, a percentage reported as inhibition, at one concentration (the size of the read-out at that concentration, not a potency): 48%
Compound 4: the middle estimate sits 4 percentage points above what was measured, and the stated range covers the measured number.
By their numbers in this assay, from the lowest: compound 2; then compounds 4, 1 and 3 (each within the scatter of the next).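

Phenyl and propyl on this carbonyl carbon are not told apart in this assay: the step of a number 9 percentage points lower from compound 3 to compound 4 (within the scatter) stays inside the scatter, so a six-membered aromatic ring of carbon can replace the open propyl chain without a readable change in the number. Benzoyl on the ring nitrogen likewise gives a number 2 percentage points lower from compound 1 to compound 4 (within the scatter) and so joins propylcarbonyl in leaving the free amine of compound 1 unchanged within the scatter, while the step of a number 28 percentage points higher from compound 2 to compound 4 (beyond the scatter) lies beyond it and leaves compound 2, with its methoxycarbonyl group, as the only compound set apart among the four. No supporting data accompany these results that would account for the separation of compound 2.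

The compounds shown leave open whether the lower number belongs to methoxycarbonyl alone or would also appear with a carboxylic acid, an amine or a longer chain such as octyl on this carbonyl carbon. With a read-out taken at a single concentration, they also leave open whether compound 1, compound 3 and compound 4 would show a stronger or weaker effect than one another at any other concentration.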